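The source may report more compounds than this note shows. Statements on the series, on what has been measured and on what is new or still open speak of the compounds shown alone.

Compound 1, `Cc1cccc(NC[C@@H]2CC3(CC3)CN2C(=O)c2nc(C)sc2-c2ccccc2)n1`, in a functional assay on CHO cells for antagonist activity at Orexin/Hypocretin receptor type 1 (Homo sapiens), read by FLIPR and calcium flux (a higher number here means a more potent compound, by a factor of ten per unit of this negative logarithm, a lower number a less potent compound), gives 7.3.
Compound 2, `Cc1nc(C(=O)N2CC3(CC3)C[C@H]2CNc2ncc(Cl)cn2)c(-c2ccccc2)s1`, in this assay gives 6.8.

Among these two measured compounds, compound 2 stands lowest: the only measured step is a number 0.50 log units lower from compound 1 to compound 2 (beyond the scatter), so compound 1 lies above it by more than the usual scatter of repeated measurements.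

Compound 3, `Cc1cc(C)nc(NC[C@@H]2CC3(CC3)CN2C(=O)c2nc(C)sc2-c2ccccc2)n1`, has not yet been measured. It differs from compound 2 in one place: 4,6-dimethylpyrimidin-2-yl in place of 5-chloropyrimidin-2-yl on an amine nitrogen. Among the measured compounds shown here, only the step from compound 1 to compound 2 bears on this change, and it does so only partly: that step swapped both the ring and its small substituent at once, replacing a methyl-bearing ring with a chlorine-bearing one, and it cost a modest amount of potency. Compound 3 keeps the pyrimidine ring of compound 2 but carries two methyl groups, as the ring of compound 1 carried one. For the measured compounds named here, no measured pair separates the effect of the ring from that of the substituent, so the expected step is small.

Compound 3 is therefore estimated to show a step of a number 0.20 log units higher from compound 2 to compound 3 (within the scatter), within the scatter, and its value in this assay is expected to be about 7, with a range from 6.5 to 7.6.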

Compound 3, negative logarithm of the antagonist equilibrium constant: 7.5
Beside the measured number, compound 3's estimate is 0.50 log units below it, and the stated range covers the measured number.
By their numbers in this assay, from the lowest: compound 2; then compounds 1 and 3 (each within the scatter of the next).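

On the amine nitrogen, the 5-chloropyrimidin-2-yl group of compound 2 and the 4,6-dimethylpyrimidin-2-yl group of compound 3 are both pyrimidines, so this pair isolates a change in what the ring carries: in this assay it gives a number 0.70 log units higher from compound 2 to compound 3 (beyond the scatter). The swap of 6-methylpyridin-2-yl for 4,6-dimethylpyrimidin-2-yl gives a number 0.20 log units higher from compound 1 to compound 3 (within the scatter), so among these three compounds a pyrimidine ring does not by itself go with the lower number, which the earlier pair could not show because it changed the ring and its substituents together. No measurement here explains why the chlorine-bearing and the methyl-bearing pyrimidines differ.

The compounds shown leave open whether both methyl groups are needed, as a pyrimidine with a single methyl group would test, and whether the lower number of compound 2 belongs to the chlorine itself or to its place on the ring. They also leave open how larger or different groups on this ring would read, such as a methoxy group, an ethyl group or a fluorine.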